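A Fluorine Added to the Phenyl Ring of Compound 2

The source may hold more compounds than are shown below. What is called first, only, known or untested is meant among the compounds shown, and "the series" means these compounds.

Measured compounds:
compound 1 `Cn1nnnc1SCC(=O)N/N=c1/scc(-c2ccccc2)n1-c1ccccc1`: 80.7%
compound 2 `O=C(CSc1nnnn1-c1ccccc1)N/N=c1/scc(-c2ccccc2)n1-c1ccccc1`: 47.1%

In a functional assay on C6 cells (Rattus norvegicus) for cytotoxicity, read by MTT assay, with a stated time of 24 h, tested at 12 ug/mL (a lower number here means a stronger effect, a higher number a weaker effect of the compound at the concentration tested), compound 1 gives 80.7%, and compound 2 gives 47.1%. Within the data shown here, the only measured step is a number 33.6 percentage points lower from compound 1 to compound 2 (beyond the scatter). Compound 2 thus stands at the lowest of the two numbers, and its nearest neighbour is compound 1, whose number lies higher by a margin beyond the scatter.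

Compound 3 `O=C(CSc1nnnn1-c1ccccc1)N/N=c1/scc(-c2ccc(F)cc2)n1-c1ccccc1` differs from compound 2 by fluoro in place of hydrogen on an aromatic carbon. Among the measured compounds shown here, none of the measured steps bears on this change: the one step on record swaps a methyl for a phenyl on an aromatic nitrogen in a different part of the shared core and says nothing about a fluoro on the phenyl ring. For the measured compounds named here, with no comparable step to lean on, the expectation in this assay is a step of a number 0.1 percentage points lower from compound 2 to compound 3 (within the scatter), that is, none beyond the scatter. Compound 3 is therefore estimated at 47%, within a range of 30% to 65%.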

Compound 3, a percentage reported as activity, at one concentration (the size of the read-out at that concentration, not a potency): 60%
For compound 3 the middle estimate is 13 percentage points below the measured one; the measured number falls inside the stated range.
By their numbers in this assay, from the lowest: compound 2; then compound 3; then compound 1.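

The change from phenyl to 4-fluorophenyl in this assay moves the read-out (a number 12.9 percentage points higher from compound 2 to compound 3 (beyond the scatter)), so this position on a six-membered aromatic ring is not silent. A single fluorine, only one added heavy atom, is enough to weaken the effect at the concentration tested. Among these compounds, until now the only step on record concerned the group on the aromatic nitrogen, and this one shows that the read-out also responds to a change on the other phenyl ring, while no measurement available here accounts for the shift.
On these data alone, whether a chlorine, a methoxy group or an amine at this position would move the number in the same direction stays open. So does whether the fluoro step would carry over to compound 1, which has methyl on the aromatic nitrogen.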